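Acetyl to methyl at an aromatic oxygen: an untested step

A few compounds are considered here, and "the series" means these few. Any claim that something is new, unique, unknown or untested is made for them only; others in the source may bear on it.

Compound 1: `C=C1[C@H](C)CCC[C@]1(C)CC[C@@]1(C)C=Cc2c(OC(C)=O)c(OC(C)=O)cc(OC)c2O1` — 0.22 ug/mL
Compound 2: `C=C1[C@H](C)CCC[C@]1(C)CC[C@@]1(C)C=Cc2c(OC(C)=O)c(OC)cc(OC(C)=O)c2O1` — limit, > 10 ug/mL

In a functional assay on COLO 205 cells (Homo sapiens) for cytotoxicity, read by MTT assay (a lower number here means a stronger inhibitor, a higher number a weaker inhibitor), compound 1 gives 0.22 ug/mL. For compound 2 this assay reports only a limit, > 10 ug/mL, so compound 2 sits at the weak end of the two numbers shown (the limit of > 10 ug/mL in this assay, at which 1 of the 2 values shown sits). Compound 3, `C=C1[C@H](C)CCC[C@]1(C)CC[C@@]1(C)C=Cc2c(OC(C)=O)c(OC)cc(OC)c2O1`, differs from compound 2 by methyl in place of acetyl on an oxygen on an aromatic ring. For the measured compounds named here, no measured pair shows this change, so any expectation is loose. The step is expected to be modest, toward a lower number, an at least 1.4-fold lower number from compound 2 to compound 3 (0.15 log units; that floor lies within the scatter), and may not exceed the scatter. Compound 3 is estimated at 7 ug/mL, with a range from 1.5 ug/mL to 30 ug/mL.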

Compound 3, half-maximal inhibitory concentration: 0.53 ug/mL
Compound 3: the middle estimate sits 13-fold (1.12 log units) above what was measured, outside the stated range (below it).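

Methyl in place of acetyl on an oxygen on an aromatic ring has no single direction in this assay: at one such oxygen the change gives an at least 18-fold lower number from compound 2 to compound 3 (1.27 log units; beyond the scatter), and at another it gives a 2.4-fold higher number from compound 1 to compound 3 (0.38 log units; beyond the scatter). The outcome of acetoxy to methoxy therefore depends on which oxygen carries it in these compounds. The value of compound 2 is a limit, so the first step has only a floor: the limit of > 10 ug/mL in this assay, at which 1 of the 3 values shown sits.

The compounds shown leave open how a free hydroxyl or a longer acyl chain such as propanoyl would fare on either oxygen.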